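This account rests on a few compounds, and the source may have more. Where it says the series, first, only, none or still open, it means among the compounds named here.

Measured in a physicochemical assay for solubility, using the shake flask method, in phosphate buffer, measured as kinetic solubility, with a stated time of 20 h, at pH 6.5; on this read-out lower numbers stand for lower solubility and higher numbers for higher solubility:
compound 1 `Fc1ccc(Nc2cc3[nH]c(-c4cccc(C(F)(F)F)c4)nc3cn2)nc1`: < 5000 nM
compound 2 `FC(F)(F)c1ccc(Nc2cc3[nH]c(-c4cccc(C(F)(F)F)c4)nc3cn2)nc1`: < 5000 nM
compound 3 `O=C(O)c1ccc(Nc2cc3[nH]c(-c4cccc(C(F)(F)F)c4)nc3cn2)nc1`: 6000 nM

Compound 2 has only a limit and no number: < 5000 nM. Compound 1 also has only a limit. Within the data shown here, the series so far shows (the limit of < 5000 nM in this assay, at which 2 of the 3 values shown sit). Compound 3 alone has a number, 6000 nM.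

Compound 4 `FC1(F)CCC(c2nc3cnc(Nc4ccc(C(F)(F)F)cn4)cc3[nH]2)C1` keeps the rest of compound 2 and changes the group on an aromatic carbon of the five-membered aromatic ring, between two ring nitrogen atoms: 3,3-difluorocyclopentyl in place of 3-(trifluoromethyl)phenyl on an aromatic carbon. Here 3,3-difluorocyclopentyl takes the place of 3-(trifluoromethyl)phenyl.

Among the measured compounds shown here, no measured step touches this place. All three concern the group that is fluoro, trifluoromethyl or carboxy: a step that the two limits leave unreadable from compound 1 to compound 2, an at least 1.2-fold higher number from compound 1 to compound 3 (0.07 log units; that floor lies within the scatter) and an at least 1.2-fold higher number from compound 2 to compound 3 (0.07 log units; that floor lies within the scatter). They therefore give no direct size for this change, and the first cannot be read at all.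

For the measured compounds named here, the only anchor is compound 3 at 6000 nM, so a modest upward move in this assay is expected. For compound 4, another limit would be no surprise. The expected change is an at least 1.2-fold higher number from compound 2 to compound 4 (0.07 log units; that floor lies within the scatter). The estimate for compound 4 is 6000 nM. The expected range for compound 4 runs from 2500 nM to 20000 nM.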

Compound 4, solubility: 120000 nM
The estimate for compound 4 lay 20-fold (1.30 log units) below the measured number; measured number above the stated range.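

In this assay, the place on an aromatic carbon of the five-membered aromatic ring, between two ring nitrogen atoms, carries a large step when 3,3-difluorocyclopentyl replaces 3-(trifluoromethyl)phenyl: an at least 24-fold higher number from compound 2 to compound 4 (1.38 log units; beyond the scatter). Among these compounds, the earlier steps all concerned the group that is fluoro, trifluoromethyl or carboxy, and none gave a readable size beyond the scatter, so this is the first sign that the read-out responds strongly to a change, and it comes from this other place. Compound 2 has a limit and not a number, so the size of this step is only a floor: the limit of < 5000 nM in this assay, at which 2 of the 4 values shown sit.

The change swaps a six-membered aromatic ring for a five-membered non-aromatic ring and also alters the fluorine count, and the compounds shown do not separate these differences. As far as these compounds go, it remains open whether unsubstituted cyclopentyl, cyclohexyl or a morpholine ring at this place would behave like 3,3-difluorocyclopentyl, and whether the step would hold with fluoro or carboxy in place of the trifluoromethyl group of compound 4.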